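This account rests on a few compounds, and the source may have more. Where it says the series, first, only, none or still open, it means among the compounds named here.

Compound 1 `CC1=CC[C@@H]([C@@](C)(O)CCCC(C)(C)NC=S)CC1`: > 100000 nM (a limit of the assay, not a number)
Compound 2 `CC1=CC[C@@H]([C@@](C)(O)CCCC(C)(C)NC(=S)N/N=C\c2ccccc2)CC1`: 48400 nM

Going by the values given here, in a functional assay on UACC-62 cells (Homo sapiens) for cytotoxicity, read by sulforhodamine B assay (on this read-out lower numbers stand for higher toxicity in this test and higher numbers for lower toxicity in this test), compound 2 gives 48400 nM, the only true number so far. Compound 1 gives no number, only a limit: the limit of > 100000 nM in this assay, at which 1 of the 2 values shown sits.

The next compound, compound 3 `CC1=CC[C@@H]([C@@](C)(O)CCCC(C)(C)NC(=S)N/N=C\c2ccc(N(C)C)cc2)CC1`, differs from compound 2 by dimethylamino in place of hydrogen on an aromatic carbon. In words, phenyl becomes 4-(dimethylamino)phenyl.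

Among the compounds with values here, only one measured step exists, an at least 2.0-fold lower number from compound 1 to compound 2 (0.31 log units; beyond the scatter). That change was made at the thiocarbonyl carbon, not on the aromatic ring, so it offers only a loose guide. Within the data shown here, no measured step covers a change on this ring. A small move towards lower numbers is therefore expected, possibly none beyond the scatter, and this assay could still return a limit.

The estimate means an expected 1.6-fold lower number from compound 2 to compound 3 (0.21 log units; within the scatter).

For compound 3 the estimated value is 30000 nM, with a range of 9000 nM to 90000 nM.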

Compound 3, concentration lethal to 50% of the cells: > 100000 nM
Compound 3 gave a limit, no number; the forecaster's own chance of this, stated with the estimate: 15%; middle value at least 3.3-fold (0.52 log units) away from the limit.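

The aromatic ring is not a silent place in this assay: dimethylamino in place of hydrogen moves the result towards lower toxicity in this test, with an at least 2.0-fold higher number from compound 2 to compound 3 (0.31 log units; beyond the scatter). Going by these compounds alone, this is the first measured change on that ring, and it runs against the direction of the only earlier step, which was made at the thiocarbonyl carbon. Compound 3 gives > 100000 nM, which is a limit of the assay and not a number, so the full size of the step stays unknown because the value sits at that limit: the limit of > 100000 nM in this assay, at which 2 of the 3 values shown sit.

Whether this shift belongs to dimethylamino alone or would follow any group at this place stays open, as this is the only group shown on the ring. Methoxy, a chlorine atom or a carboxylic acid at the same place could separate these two readings.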